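Halogen swap on the pendant aryl sulfonyl group

This account rests on a few compounds, and the source may have more. Where it says the series, first, only, none or still open, it means among the compounds named here.

Of the compounds shown here, two carry numbers so far. Compound 1, `O=S(=O)(c1ccc(F)c(Cl)c1)c1cnc2cc(F)ccc2c1-c1cccc(Cl)c1`, gives 0.66 mL/min in an ADME assay on microsomes from liver (Homo sapiens) for metabolic stability, tested at 2.5 uM; on this read-out higher numbers stand for fast clearance and lower numbers for slow clearance. Compound 2, `O=S(=O)(c1ccc(F)c(F)c1)c1cnc2cc(F)ccc2c1-c1cccc(F)c1`, gives 0.6 mL/min in this assay, the lower of the two numbers, with compound 1 only slightly higher and the gap between them within the scatter of the method; the two values therefore read as the same.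

Compound 3, `O=S(=O)(c1ccc(F)c(Cl)c1)c1cnc2cc(F)ccc2c1-c1cccc(F)c1`, remains to be measured. It differs from compound 2 in a single place: chloro in place of fluoro on an aromatic carbon. Cut one bond further out, the change reads 3,4-difluorophenyl to 3-chloro-4-fluorophenyl. Compound 3 thus shares the chloro-bearing sulfonyl ring of compound 1 and the fluoro-bearing pendant ring of compound 2.

Among the measured compounds shown here, no measured pair with this exact change exists, so the step has to be judged from the two values in hand. Since compound 1 gives 0.66 mL/min and compound 2 gives 0.6 mL/min with no difference beyond the scatter, the step from fluoro to chloro here is expected to be small, if any, in this assay: a 1.1-fold higher number from compound 2 to compound 3 (0.02 log units; within the scatter) is the expected step. Compound 3 is accordingly estimated at 0.63 mL/min, within a range of 0.35 mL/min to 1.1 mL/min.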

Compound 3, intrinsic clearance in a liver preparation (reported as CLH), per the amount of preparation that the assay uses: 0.25 mL/min
For compound 3 the middle estimate is 2.5-fold (0.40 log units) above the measured one; measured number below the stated range.
By their numbers in this assay, from the lowest: compound 3; then compounds 2 and 1 (each within the scatter of the next).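

In this assay the change from 3,4-difluorophenyl to 3-chloro-4-fluorophenyl gives a 2.4-fold lower number from compound 2 to compound 3 (0.38 log units; beyond the scatter) at this position, ortho to a fluoro group and meta to a large group. The other single change, fluoro in place of chloro on an aromatic carbon of the pendant ring, gives a 2.6-fold lower number from compound 1 to compound 3 (0.42 log units; beyond the scatter) and so also moves the number beyond the scatter, something that compound 1 and compound 2, differing in both places, could not show. Among the compounds shown here, the series so far offers no measurement that explains either step.

The compounds shown cover only chloro and fluoro at these two places, so it remains open whether a methyl, a methoxy, a nitrile or an amine on the sulfonyl ring would keep the number as low as in compound 3. Going by these compounds, it also remains open whether the chloro-for-fluoro step on the sulfonyl ring holds with other groups on the pendant ring, such as a trifluoromethyl or a plain unsubstituted phenyl.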